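Hydroxy in Place of Fluoro: Paw Edema Inhibition Compared

The source may report more compounds than this note shows. Statements on the series, on what has been measured and on what is new or still open speak of the compounds shown alone.

The two compounds measured so far in a functional assay on the whole organism (strain albino) for inhibition, with Rattus norvegicus as the target, read by paw edema, with stated times of 1 h and 2 h, at a dose of 200 mg/kg by the oral route (on this read-out lower numbers stand for less inhibition and higher numbers for more inhibition at the one dose given (going by the name of the read-out)), are:
Compound 1 `O=c1oc2ccccc2cc1C1=NN(c2ccccc2)[C@@H](c2ccccc2)C1` gives 27.2%
Compound 2 `O=c1oc2ccccc2cc1C1=NN(c2ccccc2)[C@@H](c2ccc(F)cc2)C1` gives 44.9%

Within the data shown here, compound 2 stands highest of the two numbers in this assay; its nearest neighbour is compound 1, and the single measured step, a number 17.7 percentage points higher from compound 1 to compound 2 (beyond the scatter), lies beyond the scatter. Compound 3 `O=c1oc2ccccc2cc1C1=NN(c2ccccc2)[C@@H](c2ccc(O)cc2)C1` differs from compound 2 at that same place: hydroxy in place of fluoro on an aromatic carbon. Among the measured compounds shown here, no measured step exchanges a fluoro group for a hydroxy group, so the one step on record bears only indirectly, showing that a change at this place of the ring can shift the read-out by a modest amount in either sense. For compound 3 the expected step is a number 4.9 percentage points lower from compound 2 to compound 3 (within the scatter), judged small with its direction uncertain, so the range is wide. Compound 3 is therefore expected to give about 40% in this assay, between 24% and 58%.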

Compound 3, a percentage reported as inhibition, in the whole organism at one dose (the size of the read-out at that dose, not a potency): 28.8%
The estimate for compound 3 lay 11.2 percentage points above the measured number, and the stated range covers the measured number.
By their numbers in this assay, from the lowest: compounds 1 and 3 (each within the scatter of the next); then compound 2.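

In this assay, exchanging fluoro for hydroxy on this aromatic carbon, para to a large group, gives a number 16.1 percentage points lower from compound 2 to compound 3 (beyond the scatter) and shows that not every substituent here keeps the higher number of compound 2. Hydroxy in place of hydrogen gives a number 1.6 percentage points higher from compound 1 to compound 3 (within the scatter) and so leaves compound 3 level with compound 1, which makes fluoro the only one of the three groups shown that sets its compound apart at this place. What separates fluoro from hydroxy here cannot be told from any supporting data on hand.

On these data alone, whether chloro or bromo would follow fluoro, or an amine or a methoxy group would follow hydroxy, remains open. Also open, as far as these compounds go, is how these compounds compare at other doses, since each was read at one dose only.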